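The source may report more compounds than this note shows. Statements on the series, on what has been measured and on what is new or still open speak of the compounds shown alone.

Working notes on the series. Compound 1 `COc1ccc(F)cc1Nc1cc(NC(=O)Nc2c(Cl)cccc2Cl)ncn1` gives 73.1% in a functional assay on NCI-H1581 cells (Homo sapiens) for inhibition, read by MTT assay, with a stated time of 48 h, tested at 10 uM; a lower number here means less inhibition, a higher number more inhibition at the concentration tested (going by the name of the read-out). Compound 2 `O=C(Nc1cc(Nc2ccc(F)c(Cl)c2)ncn1)Nc1c(Cl)cccc1Cl` gives 67% in this assay, and it stands level with compound 1, since a number 6.1 percentage points lower from compound 1 to compound 2 (within the scatter) lies within the scatter. Compound 3 `CCc1ccc(Nc2cc(NC(=O)Nc3c(Cl)cccc3Cl)ncn2)cc1` is not yet measured; the change is 4-ethylphenyl in place of 3-chloro-4-fluorophenyl on a nitrogen on an aromatic ring. For the measured compounds named here, the only step that bears on it is the swap of the aryl group on the same nitrogen, a number 6.1 percentage points lower from compound 1 to compound 2 (within the scatter), which left the read-out unchanged beyond the scatter. A step of a number 2 percentage points lower from compound 2 to compound 3 (within the scatter) is therefore expected, nothing beyond the scatter. Compound 3 is estimated at 65%, with a range from 50% to 80%.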

Compound 3, a percentage reported as inhibition, at one concentration (the size of the read-out at that concentration, not a potency): 38.1%
For compound 3 the middle estimate is 26.9 percentage points above the measured one; measured number below the stated range.
By their numbers in this assay, from the lowest: compound 3; then compounds 2 and 1 (each within the scatter of the next).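

The aryl group on this nitrogen is not freely exchangeable: with 4-ethylphenyl entering, this assay shows a number 28.9 percentage points lower from compound 2 to compound 3 (beyond the scatter) and a number 35 percentage points lower from compound 1 to compound 3 (beyond the scatter). Compounds 1 and 2 both carry fluorine on the aryl group, whereas 4-ethylphenyl has only carbon among its heavy atoms, though three compounds establish no pattern. Nothing at hand bears on the cause of this drop.

As far as these compounds go, it remains open whether the drop goes with the ethyl group itself or with the loss of the halogens. A plain 4-fluorophenyl or 4-methylphenyl on the same nitrogen would separate the two.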